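The compounds below may be only part of what the source reports. "The series", "measured", "known", "first", "only" and "open" are said of these compounds alone.

Compound 1 `Cc1ccc(OCC(=O)N(Cc2cccs2)c2ccn[nH]2)cc1` is the reference point here. Among the compounds with values here, in an assay on HEK293 cells for agonist activity at transient receptor potential cation channel subfamily M member 8 (Homo sapiens), read by fluorescence and calcium flux, with a stated time of 15 min (on this read-out lower numbers stand for an effect already at smaller amounts and higher numbers for an effect only at larger amounts of compound), compound 1 gives 0.2 nM, the lowest of the three numbers measured so far. Compound 2 `COc1ccc(OCC(=O)N(Cc2cccs2)c2ccn[nH]2)cc1` is the nearest neighbour: in this assay compound 2 gives 3.7 nM, and the step of a 19-fold higher number from compound 1 to compound 2 (1.27 log units; beyond the scatter) comes from a methoxy in place of a methyl on an aromatic carbon. Compound 3 `CCN(Cc1cccs1)C(=O)c1cc2cc(OC)ccc2o1` differs from compound 1 in several places at once and, in this assay, compound 3 gives 80 nM, the highest number of the set.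

Compound 4 `Cc1ccc(OCC(=O)N(O)Cc2cccs2)cc1` is not yet measured. It differs from compound 1 as follows: hydroxy in place of 1H-pyrazol-5-yl on an amide-type nitrogen. Within the data shown here, none of the measured steps touches this amide-type nitrogen, so there is no direct guide; the one measured step, on an aromatic carbon, is large, which shows that single changes can move the number a long way. Replacing a five-membered aromatic ring with a single oxygen atom at the amide-type nitrogen is a bigger structural change than that, so a sizeable rise in the number is expected, of the order of a 40-fold higher number from compound 1 to compound 4 (1.60 log units; beyond the scatter). For compound 4 in this assay the estimate is 8 nM, with a likely range from 1 nM to 60 nM.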

Compound 4, half-maximal effective concentration: 8000 nM
The estimate for compound 4 lay 1000-fold (3.00 log units) below the measured number; measured number outside the range, above it.
By their numbers in this assay, from the lowest: compound 1; then compound 2; then compound 3; then compound 4.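

In this assay, the amide-type nitrogen turns out to be far less forgiving than the aromatic carbon changed earlier: hydroxy in place of 1H-pyrazol-5-yl gives a 40000-fold higher number from compound 1 to compound 4 (4.60 log units; beyond the scatter), a much larger move than a 19-fold higher number from compound 1 to compound 2 (1.27 log units; beyond the scatter). The group that leaves and the group that enters have the same counts of hydrogen-bond donors and acceptors, so matching those counts was not enough to hold the number near that of compound 1, although the change also swaps a ring of 5 heavy atoms for a single oxygen with no ring. No supporting evidence is available to explain the size of this step.

The compounds shown leave open whether the loss follows from removing a ring as such, from removing the ring nitrogens, or from bringing in the oxygen on the amide-type nitrogen. A phenyl ring or a pyridin-2-yl group on this nitrogen would help separate the role of the ring from that of its nitrogens, while a methyl group there would show how a small group without oxygen compares with hydroxy.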